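A few compounds are considered here, and "the series" means these few. Any claim that something is new, unique, unknown or untested is made for them only; others in the source may bear on it.

Working notes on the series

In a functional assay on HCT-116 cells (Homo sapiens) for inhibition, read by luminescence and resazurin assay, with a stated time of 3 days (a lower number here means a stronger inhibitor, a higher number a weaker inhibitor), compound 1 `CNc1nc(NCc2ccc(C(=O)Nc3ccc(F)cc3)cc2)c2ccccc2n1` gives 2900 nM. Compound 2 `C=CCNc1nc(NCc2ccc(C(=O)Nc3ccc(F)cc3)cc2)c2cc(C)ccc2n1` gives 13000 nM in this assay, and compound 3 `Cc1ccc2nc(N(C)C)nc(NCc3ccc(C(=O)N4CCC(C(=O)NCc5ccc(F)cc5)CC4)cc3)c2c1` gives 5600 nM. Among the three numbers compound 2 sits at the top, the weakest inhibitor of the set: its gap to compound 3 is the smaller one and its gap to compound 1 the larger one, and both gaps lie beyond the usual scatter of the assay. Going by the values given here, no two of the measured compounds differ in only one place, so no single-change step within the measured set can be read off directly.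

Compound 4 `CCCNc1nc(NCc2ccc(C(=O)Nc3ccc(F)cc3)cc2)c2cc(C)ccc2n1` is the next compound to be read in this assay. It differs from compound 2 by ethyl in place of vinyl on a saturated chain carbon bound to a nitrogen on an aromatic ring; cut one bond further out, the change reads allyl to propyl, allylamino to propylamino. The rest of the structure, the shared core and the fluorophenyl amide arm, is unchanged.

With no measured step of this kind in the set, the expectation for this change is a step no larger than the scatter, in either direction. Compound 4 is therefore estimated at 11000 nM in this assay, with a range from 4500 nM to 27000 nM, which means an expected step of a 1.2-fold lower number from compound 2 to compound 4 (0.07 log units; within the scatter) from compound 2.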

Compound 4, half-maximal inhibitory concentration: 1200 nM
For compound 4 the middle estimate is 9.2-fold (0.96 log units) above the measured one; measured number below the stated range.
By their numbers in this assay, from the lowest: compound 4; then compounds 1 and 3 (each within the scatter of the next); then compound 2.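

In this assay, going by these compounds alone, the change from allylamino to propylamino gives an 11-fold lower number from compound 2 to compound 4 (1.03 log units; beyond the scatter) and is the first single-change step, so it is the first direct reading of how this position responds. The step is large even though vinyl and ethyl are both carbon groups with the same count of heavy atoms, no ring, no hydrogen-bond donors or acceptors and no net charge; among the counted features, only the double bond outside aromatic rings leaves. The position therefore distinguishes two groups that these counts barely separate, and no measurement available here accounts for the size of the step.

On these data alone, it remains open whether activity at this place follows the saturated chain more generally, as a butyl group, a branched isopropyl group or a cyclopropylmethyl group on the same nitrogen would show, or whether the propyl group is a specific match. A single pair also leaves open whether the same change would give a step of similar size with the other arms and core substituents seen in the series, such as the piperidine amide arm of compound 3.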